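The compounds below may be only part of what the source reports. "The series", "measured", "known", "first", "only" and "open" are said of these compounds alone.

Compound 1 `CC/C(=C(/c1ccc(/C=C/C(=O)O)cc1)c1ccc2[nH]ncc2c1)c1ccccc1` is the stronger of the two measured entries in a functional assay on MCF7 cells (Homo sapiens) for cytotoxicity, read by CellTiter-Glo, with a stated time of 5 days (a higher number here means a weaker inhibitor, a lower number a stronger inhibitor), giving 7.2 nM. Going by the values given here, compound 2 `COC/C(=C(/c1ccc(/C=C/C(=O)O)cc1)c1ccc2[nH]ncc2c1)c1ccccc1` gives 88 nM in this assay; the one measured step, a 12-fold higher number from compound 1 to compound 2 (1.09 log units; beyond the scatter), places compound 1 at the low end of the two numbers, with compound 2 as its only neighbour. That step concerns a methoxy in place of methyl on a saturated chain carbon bound to a double-bonded chain carbon, and nothing else has been varied.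

Compound 3 `CC/C(=C(/c1ccc(/C=C/C(=O)O)cc1)c1cc(C)c2[nH]ncc2c1)c1ccccc1` departs from compound 1 at a different place: methyl in place of hydrogen on an aromatic carbon. Among the compounds with values here, no measured step touches the fused ring system of the shared core, so the one step in hand does not bear on this change, and there is no basis to expect a step beyond the scatter in either direction. The estimate is that compound 3 gives 10 nM in this assay, between 3 nM and 35 nM, which means an expected step of a 1.4-fold higher number from compound 1 to compound 3 (0.14 log units; within the scatter).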

Compound 3, half-maximal inhibitory concentration: 59 nM
Estimate against measurement, compound 3: 5.9-fold (0.77 log units) below; the measured number lies above the stated range.
By their numbers in this assay, from the lowest: compound 1; then compounds 3 and 2 (each within the scatter of the next).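

Going from 1H-indazol-5-yl to 7-methyl-1H-indazol-5-yl adds a single methyl and gives an 8.2-fold higher number from compound 1 to compound 3 (0.91 log units; beyond the scatter) in this assay. The number in this series therefore responds to a change on the aromatic carbon of the fused ring system, as well as to the chain change that separates compound 1 and compound 2. No available data explain this step.

On these data alone, whether the step is specific to methyl or would also appear with another group on this aromatic carbon, such as a fluorine or an amine, remains open. Also unresolved is whether a methyl on another aromatic carbon of the fused ring system would give a similar step, and whether this change would behave the same way alongside the methoxy chain of compound 2.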